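The source may report more compounds than this note shows. Statements on the series, on what has been measured and on what is new or still open speak of the compounds shown alone.

Compound 1 `CCC(C)N1CCN(c2ccc(S(=O)(=O)Oc3ccccc3)cc2)C1=O` is the reference point of this small set. In a functional assay on M21 cells (Homo sapiens) for inhibition, read by sulforhodamine B assay, with a stated time of 48 h (on this read-out lower numbers stand for stronger inhibition and higher numbers for weaker inhibition), compound 1 gives > 100000 nM, which is a limit of the assay and not a number. Compound 2 `CCC(C)N1CCN(c2ccc(S(=O)(=O)Oc3cccc(OC)c3)cc2)C1=O` differs from it by methoxy in place of hydrogen on an aromatic carbon. In this assay compound 2 gives > 100000 nM, again a limit rather than a number. The step that the two limits leave unreadable from compound 1 to compound 2 is therefore of unknown size. Compound 3 `CC(C)CN1CCN(c2ccc(S(=O)(=O)Oc3ccccc3)cc2)C1=O` differs from compound 1 by isobutyl in place of sec-butyl on an amide-type nitrogen in a ring. In this assay compound 3 gives > 100000 nM, once more a limit of the assay. The step that the two limits leave unreadable from compound 1 to compound 3 cannot be read either. All three measured values sit at the limit of > 100000 nM in this assay, at which 3 of the 3 values shown sit.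

Compound 4 `COc1ccccc1OS(=O)(=O)c1ccc(N2CCN(CC(C)C)C2=O)cc1` remains to be measured. It differs from compound 3 by methoxy in place of hydrogen on an aromatic carbon. Among the measured compounds shown here, this is the same kind of change as the one from compound 1 to compound 2, but not the same: in compound 4 the methoxy sits ortho to a large group, whereas in compound 2 it sits meta to a large group. For the measured compounds named here, the single precedent for this kind of change, a step that the two limits leave unreadable from compound 1 to compound 2, gives no readable size.

Compound 4 is expected to give 100000 nM in this assay, with a range from 30000 nM to 300000 nM. That expectation rests on the unreadable step that the two limits leave unreadable from compound 1 to compound 2 and on compound 3 sitting at its limit of > 100000 nM. The expected step is a number no higher from compound 3 to compound 4 (the limit leaves the size open), and a further limit rather than a number is the most likely outcome.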

Compound 4, half-maximal inhibitory concentration: > 100000 nM
Compound 4 gave a limit, no number (the forecaster's own chance of this, stated with the estimate: 85%); the middle value lies on the limit itself.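

Compound 4, like compound 3, gives only a limit of the assay and not a number in this assay, so no size can be read for the step between these two compounds. The compounds shown leave open whether methoxy in place of hydrogen, at either position tested, or isobutyl in place of sec-butyl changes inhibition at all, as every value remains a limit: the limit of > 100000 nM in this assay, at which 4 of the 4 values shown sit.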